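Adding a Methoxy Group to a Melatonin Receptor Ligand

A few compounds are considered here, and "the series" means these few. Any claim that something is new, unique, unknown or untested is made for them only; others in the source may bear on it.

Measured so far:
compound 1 `CC(=O)NCC=C(c1ccccc1)c1ccccc1`: 513 nM
compound 2 `O=C(NCC=C(c1ccccc1)c1ccccc1)C1CCC1`: 912 nM

In an assay on NIH3T3 cells for displacement of a labelled ligand from melatonin receptor type 1A (Homo sapiens) (on this read-out lower numbers stand for stronger inhibition and higher numbers for weaker inhibition), compound 2 stands alongside compound 1, and the step of a 1.8-fold higher number from compound 1 to compound 2 (0.25 log units; within the scatter) shows that the two cannot be told apart. Compound 3 `COc1cccc(/C(=C\CNC(=O)C2CCC2)c2ccccc2)c1` differs from compound 2 by methoxy in place of hydrogen on an aromatic carbon. Among the measured compounds shown here, no measured step touches this aromatic ring; the only step known, a 1.8-fold higher number from compound 1 to compound 2 (0.25 log units; within the scatter), concerns the carbonyl substituent and gives no guidance here. Without a bearing step, the expectation is no change beyond the scatter, a 1.1-fold lower number from compound 2 to compound 3 (0.06 log units; within the scatter). Compound 3 is therefore estimated at 800 nM, in a range from 150 nM to 4000 nM.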

Compound 3, inhibition constant: 257 nM
For compound 3 the middle estimate is 3.1-fold (0.49 log units) above the measured one; the measured number falls inside the stated range.
By their numbers in this assay, from the lowest: compounds 3, 1 and 2 (each within the scatter of the next, the first and the last beyond it).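

Methoxy in place of hydrogen on an aromatic carbon, meta to a large group, gives a 3.5-fold lower number from compound 2 to compound 3 (0.55 log units; beyond the scatter). Among the compounds shown here, the earlier change at the carbonyl carbon, a 1.8-fold higher number from compound 1 to compound 2 (0.25 log units; within the scatter), could not be told apart from the scatter, so this is the first single change here with a readable effect, though a modest one. Nothing available explains this difference. As far as these compounds go, whether a hydroxyl or ethoxy group on this carbon would give a similar step remains open. So does whether methoxy would have the same effect with methyl on the carbonyl carbon, as in compound 1.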